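The source may hold more compounds than are shown below. What is called first, only, known or untested is meant among the compounds shown, and "the series" means these compounds.

Measured compounds in a functional assay on A-375 cells (Homo sapiens) for antiproliferative activity, read by CCK-8 assay, with a stated time of 72 h, tested at 2 uM; a lower number here means a weaker effect, a higher number a stronger effect of the compound at the concentration tested:
compound 1 `Nc1ccccc1NC(=O)c1ccc(CSC(=S)N2CCN(c3ccc(Cl)cc3)CC2)cc1` gives 32.2%
compound 2 `Nc1ccccc1NC(=O)c1ccc(CSC(=S)N(Cc2ccccc2)Cc2ccccc2)cc1` gives 10.9%
compound 3 `Nc1ccccc1NC(=O)c1ccc(CSC(=S)N2CCc3cc([N+](=O)[O-])ccc32)cc1` gives 16.9%

Compound 1 stands highest of the three numbers in this assay, with compound 3 nearest and compound 2 furthest, both beyond the scatter. Compound 4 `Nc1ccccc1NC(=O)c1ccc(CSC(=S)N2CCN(Cc3ccccc3)CC2)cc1` is not yet measured. It differs from compound 1 in one place: benzyl in place of 4-chlorophenyl on an amine nitrogen in a ring. For the measured compounds named here, no step between measured compounds with this change is known. Compound 2, which carries benzyl groups on the same kind of nitrogen outside a ring, gives 10.9%, the lowest number seen, so a drop beyond the scatter is expected from compound 1 to compound 4 in this assay. Compound 4 is expected to give 20%, in the range 8% to 34%, a step of a number 12.2 percentage points lower from compound 1 to compound 4 (beyond the scatter).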

Compound 4, a percentage reported as inhibition, at one concentration (the size of the read-out at that concentration, not a potency): 10.6%
The estimate for compound 4 lay 9.4 percentage points above the measured number; low and high end bracket the measured number.
By their numbers in this assay, from the lowest: compounds 4, 2 and 3 (each within the scatter of the next); then compound 1.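

In this assay, for the compounds shown here, benzyl in place of 4-chlorophenyl on an amine nitrogen in a ring gives a number 21.6 percentage points lower from compound 1 to compound 4 (beyond the scatter), the first step that can be read at this position. Both groups have the same heavy-atom count and one six-membered aromatic ring of carbon only, so the read-out at this position can shift beyond the scatter even between groups so alike in these counts. Nothing measured here bears on the cause of this step.

Open, on these data alone, is whether the step follows the loss of chlorine or the added carbon link. Plain phenyl and 4-chlorobenzyl on the same nitrogen would separate the two.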